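The source may report more compounds than this note shows. Statements on the series, on what has been measured and on what is new or still open speak of the compounds shown alone.

Compound 1 `O=C(Nc1ccc(Cl)cc1F)c1cc(Cl)ccc1O`: 2120 nM
Compound 2 `O=C(Nc1ccc(Br)cc1F)c1cc(F)ccc1O`: 1860 nM
Compound 3 `O=c1oc2ccccc2c(=O)n1-c1ccc(Cl)cc1F`: 7100 nM

In a functional assay on RAW264.7 cells (Mus musculus) for inhibition, read by microscopy, with a stated time of 4 days, in the presence of a further agent that is not named here (on this read-out higher numbers stand for weaker inhibition and lower numbers for stronger inhibition), compound 1 lies within the scatter of compound 2, and both numbers stand clearly lower than that of compound 3. Compound 4 `O=C(Nc1ccc(Cl)cc1F)c1ccccc1O` has not yet been measured. It departs from compound 1 by one change, hydrogen in place of chloro on an aromatic carbon. Among the compounds with values here, no measured pair isolates this change, and no measured compound has hydrogen at that carbon. Compound 2 has fluoro there and gives 1860 nM, though it also differs elsewhere. A modest rise towards weaker inhibition is therefore expected, and the estimated change is a 1.5-fold higher number from compound 1 to compound 4 (0.18 log units; within the scatter). Compound 4 is expected at 3200 nM, with an estimated range of 1400 nM to 7500 nM.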

Compound 4, half-maximal inhibitory concentration: 10000 nM
Beside the measured number, compound 4's estimate is 3.1-fold (0.49 log units) below it; measured number above the stated range.
By their numbers in this assay, from the lowest: compounds 2 and 1 (each within the scatter of the next); then compounds 3 and 4 (each within the scatter of the next).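

In this assay, hydrogen in place of chloro on this aromatic carbon, para to a hydroxy group, gives a 4.7-fold higher number from compound 1 to compound 4 (0.67 log units; beyond the scatter). Within the data shown here, this is the first isolated reading of this carbon, and it shows that, in this pair, chloro there goes with stronger inhibition than hydrogen. Nothing measured here explains the step.

The compounds shown leave open how a methoxy group or an amine on this carbon would read on the core of compound 1. They also leave open whether the step holds when the core changes elsewhere.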